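Hydroxy for sulfanyl in a naphthylthio quinazoline

The compounds below may be only part of what the source reports. "The series", "measured", "known", "first", "only" and "open" are said of these compounds alone.

Measured compounds:
- compound 1: `Nc1nc(S)nc2ccc(Sc3ccc4ccccc4c3)cc12`, 5.52
- compound 2: `Sc1nc(S)c2cc(Sc3ccc4ccccc4c3)ccc2n1`, 5.05

In an assay for inhibition of Dihydrofolate reductase (Homo sapiens) (on this read-out lower numbers stand for lower potency and higher numbers for higher potency (the scale is a negative logarithm)), compound 2 stands lowest of the two numbers; its nearest neighbour is compound 1, whose value lies higher by a number 0.47 log units lower from compound 1 to compound 2 (beyond the scatter). Compound 3, `Oc1nc(S)nc2ccc(Sc3ccc4ccccc4c3)cc12`, differs from compound 2 by hydroxy in place of sulfanyl on an aromatic carbon. For the measured compounds named here, the only measured step, from compound 1 to compound 2, swapped a different group at the same place and bears only loosely on this change. Going by the values given here, no measured step mirrors it, so compound 3 is expected to stay near compound 2, with an estimated step of a number 0.05 log units lower from compound 2 to compound 3 (within the scatter) and a value of 5 (range 4.5 to 5.5).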

Compound 3, logarithm of the reciprocal of the active concentration, log(1/C): 5
The estimate for compound 3 equals the measured number at the digits printed, and the stated range covers the measured number.
By their numbers in this assay, from the lowest: compounds 3 and 2 (each within the scatter of the next); then compound 1.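

In this assay, hydroxy in place of sulfanyl on this aromatic carbon gives a number 0.05 log units lower from compound 2 to compound 3 (within the scatter) and so does not separate the two groups. Hydroxy in place of amino gives a number 0.52 log units lower from compound 1 to compound 3 (beyond the scatter) and sulfanyl in place of amino gives a number 0.47 log units lower from compound 1 to compound 2 (beyond the scatter) so among these three groups amino alone stands apart. No measurement on hand gives a reason for these steps. The compounds shown leave open whether a methylamino or a methoxy group here would keep the number of compound 1 or match that of compound 3.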